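The source may hold more compounds than are shown below. What is called first, only, known or untested is meant among the compounds shown, and "the series" means these compounds.

Compound 1 (`CCOC(=O)c1cc(CCCOc2ccc(-c3noc(C(F)(F)F)n3)cc2OC)on1`): > 100000 nM (a limit)
Compound 2 (`CNC(=O)c1cc(CCCOc2c(C)cc(-c3noc(C(F)(F)F)n3)cc2C)on1`): > 100000 nM (a limit)
Compound 3 (`COc1cc(-c2noc(C(F)(F)F)n2)ccc1OCCCc1cc(C(=O)N(C)C)no1`): 68000 nM

These values come from an ADME assay on HeLa cells (Homo sapiens) for cytotoxicity, read by crystal violet staining, with a stated time of 72 h (on this read-out higher numbers stand for lower toxicity in this test and lower numbers for higher toxicity in this test), and describe the compounds on that read-out. Compound 1 gives no number, only a limit, and it sits at the limit of > 100000 nM in this assay, at which 2 of the 3 values shown sit.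

Compound 4 (`CCOC(=O)c1cc(CCCOc2ccc(-c3noc(C(F)(F)F)n3)cc2NC(C)=O)on1`) differs from compound 1 at one place, with acetamido in place of methoxy on an aromatic carbon.

Among the measured compounds shown here, the only measured step, an at least 1.4-fold lower number from compound 1 to compound 3 (0.16 log units; that floor lies within the scatter), lies elsewhere, on a carbonyl carbon, and its floor is within the scatter. For the measured compounds named here, no measured step covers this change, so no step beyond the scatter is expected. The expected step is a number no higher from compound 1 to compound 4 (the limit leaves the size open).

For compound 4 the estimated value is 100000 nM, with an expected range from 45000 nM to 200000 nM.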

Compound 4, half-maximal cytotoxic concentration: > 100000 nM
Compound 4: no number, only a limit; the forecaster's own chance of this, stated with the estimate: 60%; the middle value lies on the limit itself.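

In this assay, among the compounds shown here, compound 1 and compound 4 each give only a limit, so no step between them can be read. The compounds shown leave open whether acetamido in place of methoxy on an aromatic carbon changes this read-out at all.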